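Swapping the Amide Substituent: Acrylamide Out, Dichlorophenyl In

The source may report more compounds than this note shows. Statements on the series, on what has been measured and on what is new or still open speak of the compounds shown alone.

Of the compounds shown here, three sharing one core have been tested in a functional assay on PC-3 cells (Homo sapiens) for inhibition, read by MTT assay, with a stated time of 72 h; a lower number here means a stronger inhibitor, a higher number a weaker inhibitor. Compound 2 `C=CC(=O)Nc1cccc(NC(=O)CSc2nc(Nc3ccccc3)c3ccccc3n2)c1` gives 8740 nM, the lowest of the three numbers. Compound 1 `O=C(CSc1nc(Nc2ccccc2)c2ccccc2n1)Nc1ccccc1Cl` gives 14600 nM, and compound 3 `O=C(CSc1nc(Nc2ccccc2)c2ccccc2n1)Nc1ccc([N+](=O)[O-])cc1` gives 25000 nM. The step of a 1.7-fold lower number from compound 1 to compound 2 (0.22 log units; within the scatter) stays within the scatter, whereas a 2.9-fold higher number from compound 2 to compound 3 (0.46 log units; beyond the scatter) is modest but real. Compound 4 `O=C(CSc1nc(Nc2ccccc2)c2ccccc2n1)Nc1ccc(Cl)c(Cl)c1` is the next variant: 3,4-dichlorophenyl in place of 3-((vinylcarbonyl)amino)phenyl on an amide-type nitrogen. The closest guide is a 1.7-fold lower number from compound 1 to compound 2 (0.22 log units; within the scatter) read in reverse, because compound 1 gives 14600 nM while also carrying a chlorine-bearing phenyl on that nitrogen. A small rise, within the scatter, is expected. Compound 4 is therefore estimated at 14000 nM, likely between 6000 nM and 35000 nM, an expected step of a 1.6-fold higher number from compound 2 to compound 4 (0.20 log units; within the scatter).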

Compound 4, half-maximal inhibitory concentration: 12100 nM
The estimate for compound 4 lay 1.2-fold (0.06 log units) above the measured number, within the range that was stated.
By their numbers in this assay, from the lowest: compounds 2, 4, 1 and 3 (each within the scatter of the next, the first and the last beyond it).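

The 3,4-dichlorophenyl group has no hydrogen-bond donor or acceptor and no double bond outside its ring, yet it cannot be told apart from the 3-((vinylcarbonyl)amino)phenyl group on this amide-type nitrogen (a 1.4-fold higher number from compound 2 to compound 4 (0.14 log units; within the scatter)). It also stays within the scatter of the 2-chlorophenyl group (a 1.2-fold lower number from compound 1 to compound 4 (0.08 log units; within the scatter)). The 4-nitrophenyl group does separate from it, modestly (a 2.1-fold lower number from compound 3 to compound 4 (0.32 log units; beyond the scatter)).

No measurement available here explains these numbers. On these data alone, whether an amine, a carboxylic acid or a longer alkyl chain on this nitrogen would hold these numbers remains open.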